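Halogen pattern swap on the aryl hydrazone of compound 3

A few compounds are considered here, and "the series" means these few. Any claim that something is new, unique, unknown or untested is made for them only; others in the source may bear on it.

Measured compounds, cytotoxicity on colon carcinoma cells:
compound 1 `COc1cc2c(Oc3ccc(NC(=O)N/N=C/c4ccc(C(F)(F)F)cc4)cc3F)ccnc2cc1OCCCN1CCCC1`: 810 nM
compound 2 `COc1ccc(/C=N/NC(=O)Nc2ccc(Oc3ccnc4cc(OCCCN5CCC(C)CC5)c(OC)cc34)c(F)c2)cc1`: 610 nM
compound 3 `COc1cc2c(Oc3ccc(NC(=S)N/N=C/c4ccc(F)c(F)c4)cc3F)ccnc2cc1OCCCN1CCCCC1`: 610 nM

In a functional assay on HT-29 cells (Homo sapiens) for cytotoxicity, read by MTT assay, with a stated time of 72 h (on this read-out lower numbers stand for stronger inhibition and higher numbers for weaker inhibition), compound 3 gives 610 nM, level with compound 2 at the digits shown, and its gap to compound 1 lies within the scatter, so no order among the three can be claimed. Compound 4 `COc1cc2c(Oc3ccc(NC(=S)N/N=C/c4ccc(F)cc4Cl)cc3F)ccnc2cc1OCCCN1CCCCC1` differs from compound 3 in one place: 2-chloro-4-fluorophenyl in place of 3,4-difluorophenyl on a carbon with a double bond to nitrogen. For the measured compounds named here, no step between measured compounds bears on this change, and the three measured values sit close together. The step from compound 3 to compound 4 is therefore expected to be small, a 1.1-fold higher number from compound 3 to compound 4 (0.03 log units; within the scatter), with no direction beyond the scatter. Compound 4 is estimated at 650 nM in this assay, with a range from 300 nM to 1400 nM.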

Compound 4, half-maximal inhibitory concentration: 420 nM
The estimate for compound 4 lay 1.5-fold (0.19 log units) above the measured number; low and high end bracket the measured number.
By their numbers in this assay, from the lowest: compounds 4, 2, 3 and 1 (each within the scatter of the next).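

In this assay the exchange of 3,4-difluorophenyl for 2-chloro-4-fluorophenyl gives a 1.5-fold lower number from compound 3 to compound 4 (0.16 log units; within the scatter) at this position. For the compounds shown here, this is the first single-place step, and on this read-out the two aryl groups cannot be told apart. No measurement available here accounts for the step.

Still open, on these data alone, is whether a saturated ring such as cyclohexyl, or an aryl group carrying a carboxylic acid or a dimethylamino group, would move the number beyond the scatter at this position.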